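The source may report more compounds than this note shows. Statements on the series, on what has been measured and on what is new or still open speak of the compounds shown alone.

Measured compounds:
- Compound 1 `N#Cc1ccn2c(-c3ccccc3)c(-c3ccccc3)c(OCc3cccc(Cl)c3)c2c1` — in an assay for inhibition of Polyunsaturated fatty acid lipoxygenase ALOX15 (Oryctolagus cuniculus) (on this read-out higher numbers stand for weaker inhibition and lower numbers for stronger inhibition), compound 1 gives "not determined" (no result reported)
- Compound 2 `Cc1ccc(S(=O)(=O)Oc2c(-c3ccccc3)c(-c3ccccc3)n3ccc(C#N)cc23)cc1` — in this assay compound 2 gives 25000 nM
- Compound 3 `N#Cc1ccn2c(-c3ccccc3)c(-c3ccccc3)c(OCOC(COCc3ccccc3)COCc3ccccc3)c2c1` — in this assay compound 3 gives "not determined" (no result reported)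

Only compound 2 comes with a number in this assay. Compound 1 and compound 3 share the same core but were not given a result, so there is nothing to compare compound 2 against, and its value stands alone: a weak inhibition, far from the range in which strong inhibitors are usually found.

Compound 4 `N#Cc1ccn2c(-c3ccccc3)c(-c3ccccc3)c(C(O)c3ccccc3)c2c1` keeps that core and changes one position: hydroxy(phenyl)methyl in place of ((4-methylphenyl)sulfonyl)oxy on an aromatic carbon

Within the data shown here, no step between two measured compounds is known, so the size of this change cannot be read from the data. The expectation is therefore cautious: the step from compound 2 to compound 4 in this assay is expected to be small, in the direction of somewhat stronger inhibition, but possibly no larger than the scatter, as a 1.7-fold lower number from compound 2 to compound 4 (0.22 log units; within the scatter) states. On that basis compound 4 is estimated at 15000 nM, with a plausible range from 3000 nM to 60000 nM.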

Compound 4, half-maximal inhibitory concentration: 48000 nM
Beside the measured number, compound 4's estimate is 3.2-fold (0.51 log units) below it, within the range that was stated.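

Among these compounds, this is the first step that can be read at this position on the shared core: in this assay, hydroxy(phenyl)methyl in place of ((4-methylphenyl)sulfonyl)oxy gives a 1.9-fold higher number from compound 2 to compound 4 (0.28 log units; within the scatter). The two groups differ in heavy atoms and in their counts of hydrogen-bond donors and acceptors, yet the step stays within the usual scatter, so this read-out does not separate the two compounds. No measurement at hand gives a reason for this result.

Compound 1 and compound 3 carry no number, so steps involving them cannot be read. Going by these compounds, it remains open whether a quite different group at this position, such as an amine or a carboxylic acid, would move the read-out beyond the scatter.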